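The source may hold more compounds than are shown below. What is called first, only, known or untested is meant among the compounds shown, and "the series" means these compounds.

Compound 1, `O=C(COc1c(-c2ccccc2)oc2ccccc2c1=O)Nc1ccccc1`, and compound 3, `O=C(COc1ccc2c(=O)c(-c3ccccc3)coc2c1)Nc1ccccc1`, are built from the same atoms joined differently, and the difference between the two cores is not broken down here. In a functional assay on NPC-TW01 cells (Homo sapiens) for antiproliferative activity, read by MTT assay, with a stated time of 72 h (a higher number here means a weaker inhibitor of growth, a lower number a stronger inhibitor of growth), compound 1 reaches only the limit of the measurement, > 10000 nM. In this assay compound 3 likewise gives only the limit, > 10000 nM. Compound 2, `O=C(COc1c(-c2ccccc2)oc2ccccc2c1=O)Nc1ccc(F)cc1`, carries the change fluoro in place of hydrogen on an aromatic carbon relative to compound 1, and in this assay compound 2 gives 9500 nM; the step is an at least 1.0-fold lower number from compound 1 to compound 2 (0.02 log units; that floor lies within the scatter), a step whose size is bounded by the limit of > 10000 nM in this assay, at which 2 of the 3 values shown sit, so that little can be read from it. Compound 4, `O=C(COc1ccc2c(=O)c(-c3ccccc3)coc2c1)Nc1ccc(F)cc1`, stands to compound 3 as compound 2 stands to compound 1, through (fluoro in place of hydrogen on an aromatic carbon), the same change made at the same kind of place. For the measured compounds named here, because compound 3 sits at the limit > 10000 nM and because the one earlier step was an at least 1.0-fold lower number from compound 1 to compound 2 (0.02 log units; that floor lies within the scatter), the step that the limit leaves unreadable from compound 3 to compound 4 is expected to be small. Compound 4 is therefore estimated at 11000 nM, within 6000 nM to 25000 nM, and it may well return only a limit again.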

Compound 4, concentration for 50% growth inhibition: 550 nM
Compound 4: the middle estimate sits 20-fold (1.30 log units) above what was measured; the measured number lies below the stated range.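

On the core of compound 3 in this assay, fluoro in place of hydrogen gives an at least 18-fold lower number from compound 3 to compound 4 (1.25 log units; beyond the scatter), so on this core the change from anilino to (4-fluorophenyl)amino carries a clear gain in growth inhibition. Set beside the same change on the core of compound 1, the result does not show that the two cores respond differently: the same change on two cores in this assay, an at least 1.0-fold lower number (0.02 log units; that floor lies within the scatter) from compound 1 to compound 2 and an at least 18-fold lower number (1.25 log units; beyond the scatter) from compound 3 to compound 4; the limit leaves it open whether they differ. Nor does it fix the true size of either step, and so it shows no rule for carrying this change from one core to another, since both steps start from a limit of the measurement: the limit of > 10000 nM in this assay, at which 2 of the 4 values shown sit.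

The compounds shown leave open whether a chloro group or an amine on the same ring would follow fluoro on either core. They also leave open whether a longer chain in the linker that carries the amide would keep the activity of compound 4.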